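The source may hold more compounds than are shown below. What is called first, only, known or untested is meant among the compounds shown, and "the series" means these compounds.

Compound 1 `CCOc1ncc(-c2nc(C(F)(F)F)sc2N2CCN(C(=O)Cn3cnc4ccccc43)[C@H](C)C2)cn1` and compound 2 `CCOc1ncc(-c2nc(C(F)(F)F)sc2N2CCN(C(=O)Cn3ccc4cccnc43)[C@H](C)C2)cn1` share a core and differ only in the two-ring group attached to the saturated chain carbon bound to the carbonyl carbon. In a functional assay on U2OS cells for antagonist activity at C-X-C chemokine receptor type 3 (Homo sapiens), read by beta-arrestin recruitment (a higher number here means a weaker inhibitor, a lower number a stronger inhibitor), compound 1 gives 49 nM, and compound 2 gives 47 nM; the step of a 1.0-fold lower number from compound 1 to compound 2 (0.02 log units; within the scatter) lies within the scatter, so compound 2 stands level with compound 1 rather than apart from it. Going by the values given here, compound 3 `CCOc1ncc(-c2nc(C(F)(F)F)sc2N2CCN(C(=O)Cn3ccc4cnccc43)[C@H](C)C2)cn1` again changes only this group: a group of 9 heavy atoms (7 carbon, 2 nitrogen; one five-membered aromatic ring with 1 hetero atom, one six-membered aromatic ring with 1 hetero atom) in place of a group of 9 heavy atoms (7 carbon, 2 nitrogen; one five-membered aromatic ring with 1 hetero atom, one six-membered aromatic ring with 1 hetero atom), on a saturated chain carbon bound to a carbonyl carbon. Among the compounds with values here, since the one comparable step changed nothing beyond the scatter, compound 3 is expected to show a step of a 1.1-fold higher number from compound 2 to compound 3 (0.03 log units; within the scatter), and its estimated value in this assay is 50 nM, between 25 nM and 100 nM.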

Compound 3, half-maximal inhibitory concentration: 23 nM
Beside the measured number, compound 3's estimate is 2.2-fold (0.34 log units) above it; measured number outside the range, below it.
By their numbers in this assay, from the lowest: compound 3; then compounds 2 and 1 (each within the scatter of the next).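

The two-ring group at this position is not interchangeable after all: with the same atoms joined differently, this assay shows a modest gain (a 2.0-fold lower number from compound 2 to compound 3 (0.31 log units; beyond the scatter)). The gain also holds against the group of compound 1 (a 2.1-fold lower number from compound 1 to compound 3 (0.33 log units; beyond the scatter)). So the arrangement of atoms within the group matters here, not only their number, but nothing available explains this difference.

Still open, as far as these compounds go, is whether a single phenyl ring at this position would keep the activity. Also open, from the compounds shown here alone, is whether an amine or a carboxylic acid on the two-ring group would change it further.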